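The compounds below may be only part of what the source reports. "The series", "measured", "known", "first", "only" and "open" are said of these compounds alone.

Three compounds share one core and differ only in the group attached to one aromatic carbon. Compound 1 `CC(C(=O)NCc1ccc(C(C)(C)C)cc1N1CCCCC1)c1ccc(NS(C)(=O)=O)c(F)c1` carries piperidin-1-yl there, and in an assay on cells for antagonist activity at transient receptor potential cation channel subfamily V member 1 (Homo sapiens), read by FLIPR and calcium flux, with a stated time of 6 min (a lower number here means a stronger inhibitor, a higher number a weaker inhibitor), compound 1 gives 1.9 nM. Compound 2 `CC(C(=O)NCc1ccc(C(C)(C)C)cc1N1CCN(c2ccccc2)CC1)c1ccc(NS(C)(=O)=O)c(F)c1` carries 4-phenylpiperazin-1-yl instead, and in this assay compound 2 gives 0.8 nM, so that a 2.4-fold lower number from compound 1 to compound 2 (0.38 log units; beyond the scatter). Compound 3 `CCCCCCOc1cc(C(C)(C)C)ccc1CNC(=O)C(C)c1ccc(NS(C)(=O)=O)c(F)c1` carries hexyloxy, and in this assay compound 3 gives 0.5 nM. Among the three numbers compound 3 has the lowest: on one side a 1.6-fold lower number from compound 2 to compound 3 (0.20 log units; within the scatter), while on the other side a 3.8-fold lower number from compound 1 to compound 3 (0.58 log units; beyond the scatter), so compound 3 is clearly stronger than compound 1 but cannot be separated from compound 2.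

Compound 4 `CC(C)CCOc1cc(C(C)(C)C)ccc1CNC(=O)C(C)c1ccc(NS(C)(=O)=O)c(F)c1` keeps the chain ether but shortens and branches it: isopropyl in place of butyl on a saturated chain carbon, two bonds along the chain from an oxygen on an aromatic ring. Among the compounds with values here, none of the measured steps alters the chain itself; the steps from compound 1 and from compound 2 to compound 3 each exchange a whole ring-bearing group for the chain, and both were modest or within the scatter. They give no direct guide to moving one chain carbon into a branch. The expectation for this assay is therefore a step of no size beyond the scatter, in either direction. For compound 4 the estimated value in this assay is 0.6 nM, with a range from 0.25 nM to 1.5 nM, which is expected to mean a 1.2-fold higher number from compound 3 to compound 4 (0.08 log units; within the scatter).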

Compound 4, inhibition constant: 0.6 nM
For compound 4 middle estimate and measured number coincide at the digits printed; the range from low to high includes it.
By their numbers in this assay, from the lowest: compounds 3, 4 and 2 (each within the scatter of the next); then compound 1.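

In this assay, the step from the straight hexyloxy chain to the branched isopentyloxy chain gives a 1.2-fold higher number from compound 3 to compound 4 (0.08 log units; within the scatter) and so cannot be told apart from no change, which means that this chain carbon, two bonds along the chain from an oxygen on an aromatic ring, can carry isopropyl in place of butyl without a measurable loss. The earlier compounds shown here showed only that a straight chain could replace a ring-bearing group, whereas the branched ether now gives a 1.3-fold lower number from compound 2 to compound 4 (0.12 log units; within the scatter) and still stays level with the phenylpiperazine compound, while a 3.2-fold lower number from compound 1 to compound 4 (0.50 log units; beyond the scatter) shows that it keeps a real edge over the piperidine compound, as the straight chain did. Nothing measured alongside these numbers speaks to what lies behind them.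

As far as these compounds go, this is a single branch on a single chain, so it remains open whether a bulkier ending such as tert-butyl or a cyclohexyl ring would fit equally well. From the compounds shown here alone, it is also open whether a much shorter methoxy group, or a chain ending in an amine or a carboxylic acid, would hold the number at this level.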